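Triazole-Linked Cinnamic Acids: Cytotoxicity on A-431 Cells

The source may hold more compounds than are shown below. What is called first, only, known or untested is meant among the compounds shown, and "the series" means these compounds.

Measured compounds:
compound 1 `COc1ccc(-n2cc(COc3c(/C=C\C(=O)O)ccc(OC)c3CC=C(C)C)nn2)cc1`: "not determined" (no result reported)
compound 2 `COc1ccc(/C=C\C(=O)O)c(OCc2cn(-c3cccc(C#N)c3)nn2)c1CC=C(C)C`: 22900 nM

Compound 1 has no single number in a functional assay on A-431 cells (Homo sapiens) for cytotoxicity, read by MTT assay, with a stated time of 24 h (on this read-out lower numbers stand for stronger inhibition and higher numbers for weaker inhibition), so it stands nowhere on the scale; only compound 2 gives a value there, 22900 nM, which is weak. Compound 3 `COc1ccc(/C=C\C(=O)O)c(OCc2cn(-c3ccccc3F)nn2)c1CC=C(C)C` arises from compound 1 by 2-fluorophenyl in place of 4-methoxyphenyl on an aromatic nitrogen. Among the measured compounds shown here, with no measured step between the two measured compounds, no direction is expected for this change beyond the scatter in this assay. Compound 3 is estimated at 25000 nM, within a range from 8000 nM to 80000 nM, resting on the weak value of compound 2.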

Compound 3, half-maximal inhibitory concentration: 12400 nM
The estimate for compound 3 lay 2.0-fold (0.30 log units) above the measured number, within the range that was stated.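

With 2-fluorophenyl in place of 3-cyanophenyl on the aromatic nitrogen, this assay gives a 1.8-fold lower number from compound 2 to compound 3 (0.27 log units; within the scatter), so these two groups cannot be told apart at this position. Compound 1 has no number, so the change from 4-methoxyphenyl cannot be read. No measurement shown here offers an explanation for this result.

From the compounds shown here alone, it remains open whether an amine on this phenyl ring, or an alkyl chain in place of the ring, would give a value clearly apart from these. Going by these compounds, the standing of 4-methoxyphenyl at this position also remains open.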